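The source may report more compounds than this note shows. Statements on the series, on what has been measured and on what is new or still open speak of the compounds shown alone.

Measured compounds:
- compound 1 `COC(=O)CCNC(=O)CN1CN(c2ccccc2)C2(CCN(C(=O)c3ccc(C(C)(C)C)cc3)CC2)C1=O`: "not determined" (no result reported) in an assay on HEK293 cells for displacement of a labelled ligand from NPC1-like intracellular cholesterol transporter 1 (Homo sapiens); on this read-out lower numbers stand for stronger inhibition and higher numbers for weaker inhibition
- compound 2 `CC(C)(C)c1ccc(C(=O)N2CCC3(CC2)C(=O)N(CC(=O)N2CCCCC2CCO)CN3c2ccccc2)cc1`: 6100 nM in this assay

For the measured compounds named here, compound 2 holds the only number in this assay; compound 1 gives no figure to set beside it, so compound 2 stands alone on this read-out. Compound 3 `CC1CCCN(C(=O)CN2CN(c3ccccc3)C3(CCN(C(=O)c4ccc(C(C)(C)C)cc4)CC3)C2=O)C1` is not yet measured. Its change from compound 2 is 3-methylpiperidin-1-yl in place of 2-(2-hydroxyethyl)piperidin-1-yl on a carbonyl carbon. Going by the values given here, no step between measured compounds exists to calibrate this change. For compound 3 a small shift toward weaker inhibition is expected, close to the scatter, as a 1.2-fold higher number from compound 2 to compound 3 (0.09 log units; within the scatter). The estimate for compound 3 in this assay is 7500 nM, with a range from 2500 nM to 22000 nM.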

Compound 3, half-maximal inhibitory concentration: 12000 nM
Estimate against measurement, compound 3: 1.6-fold (0.20 log units) below, within the range that was stated.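

In this assay, 3-methylpiperidin-1-yl in place of 2-(2-hydroxyethyl)piperidin-1-yl on the carbonyl carbon gives a 2.0-fold higher number from compound 2 to compound 3 (0.29 log units; within the scatter). This first readable step at this place shows that the hydrogen-bond donor and acceptor of the leaving group can go, with a methyl entering, and the two values stay within the scatter of each other. No measurement on hand accounts for this result. Open, on these data alone, is whether unsubstituted piperidin-1-yl would also stay within the scatter. Equally open, as far as these compounds go, is whether a carboxylic acid or a primary amine on the piperidine would move the number beyond it.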